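A few compounds are considered here, and "the series" means these few. Any claim that something is new, unique, unknown or untested is made for them only; others in the source may bear on it.

Measured so far in an assay on isolated protein for binding affinity to leukotriene B4 receptor 1 (Homo sapiens), tested at 1 uM; on this read-out lower numbers stand for less inhibition and higher numbers for more inhibition at the one concentration tested (going by the name of the read-out):
compound 1 `CC(=O)c1ccc(OCCCCC#N)cc1O`, 0%
compound 2 `CCc1cc(C(C)=O)c(O)cc1OCCCCC#N`, 57%

Compound 2 stands highest of the two numbers; the nearest is compound 1, with 0%. For the measured compounds named here, the one measured step, a number 57 percentage points higher from compound 1 to compound 2 (beyond the scatter), concerns ethyl on an aromatic carbon and does not touch the chain end. Compound 3 `CCc1cc(C(C)=O)c(O)cc1OCCCC(C)(C)c1nnn[nH]1` differs from compound 2 by 1-(1H-tetrazol-5-yl)-1-methylethyl in place of cyanomethyl on a saturated chain carbon, three bonds along the chain from an oxygen on an aromatic ring. Going by the values given here, no measured step bears on this change, so its direction and size are not readable from the numbers in hand. Compound 3 is therefore expected near the level of compound 2, at 60% with a wide range of 25% to 95%. The expected step is a number 3 percentage points higher from compound 2 to compound 3 (within the scatter), within the scatter.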

Compound 3, a percentage reported as inhibition, at one concentration (the size of the read-out at that concentration, not a potency): 76%
Compound 3: middle estimate off by 16 percentage points, on the low side; the range from low to high includes it.
By their numbers in this assay, from the lowest: compound 1; then compound 2; then compound 3.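

On a saturated chain carbon, three bonds along the chain from an oxygen on an aromatic ring, 1-(1H-tetrazol-5-yl)-1-methylethyl in place of cyanomethyl gives a number 19 percentage points higher from compound 2 to compound 3 (beyond the scatter) in this assay. The nitrile is therefore not needed at this position, and a larger group with a five-membered aromatic ring is accepted on top of the ethyl-bearing core. Nothing available accounts for this gain.

The ring and the branched carbon enter together, so their separate shares cannot be read. On these data alone, whether a carboxylic acid in place of the tetrazole, or a longer chain, would keep this level remains open.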